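A few compounds are considered here, and "the series" means these few. Any claim that something is new, unique, unknown or untested is made for them only; others in the source may bear on it.

Compound 1, `CN(C)C(=O)c1cc2cnc(Nc3ccc(S(=O)(=O)NCCCN=C=S)cc3)nc2n1C1CCCC1`, was tested in a functional assay on A549 cells (Homo sapiens) for inhibition, read by CCK-8 assay, with a stated time of 72 h, tested at 1 uM (a lower number here means a weaker effect, a higher number a stronger effect of the compound at the concentration tested), where compound 1 gives 58.9%. Among the two compounds measured, compound 1 stands highest; its nearest neighbour, compound 2, `CN(C)C(=O)c1cc2cnc(Nc3ccc(C(=O)NCCCCCCCN=C=S)cc3F)nc2n1C1CCCC1`, gives 0.05%, a gap well beyond the usual scatter. Compound 3, `CN(C)C(=O)c1cc2cnc(Nc3ccc(N=C=S)cc3)nc2n1C1CCCC1`, has not yet been measured in this assay. It differs from compound 1 in a single place: a group of 3 heavy atoms (1 carbon, 1 nitrogen, 1 sulfur; no ring) in place of a group of 10 heavy atoms (4 carbon, 2 nitrogen, 2 oxygen, 2 sulfur; no ring), on an aromatic carbon. For the measured compounds named here, no pair of measured compounds shows a step of this kind, so the size of the step has no direct precedent. The two measured values show that compounds sharing the core can give either a strong or a near-zero reading, which leaves wide room for compound 3. The expected step is a number 20.9 percentage points lower from compound 1 to compound 3 (beyond the scatter), a moderate fall rather than none. The estimate for compound 3 is 38%, with a likely range from 8% to 70%.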

Compound 3, a percentage reported as inhibition, at one concentration (the size of the read-out at that concentration, not a potency): 44.4%
Beside the measured number, compound 3's estimate is 6.4 percentage points below it; low and high end bracket the measured number.
By their numbers in this assay, from the lowest: compound 2; then compound 3; then compound 1.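

In this assay, the change at this position gives a number 14.5 percentage points lower from compound 1 to compound 3 (beyond the scatter), so the group of 10 heavy atoms is not required for a clear reading: with only the group of 3 heavy atoms on the aromatic carbon, compound 3 still gives 44.4%. The larger group therefore adds to the reading, but the effect does not depend on it entirely, and a single-concentration reading like this one is not a measure of potency. No measurement shown here explains why the reading falls.

On these data alone, because the whole group changes in one step, it remains open which of its parts matters. As far as these compounds go, it is also open whether the group of 3 heavy atoms is itself needed, which an amine or a carboxylic acid at this position could test.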